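A few compounds are considered here, and "the series" means these few. Any claim that something is new, unique, unknown or untested is made for them only; others in the source may bear on it.

Measured so far:
Compound 1, `CCNC(=O)c1cc(C(=O)NC)c(=O)n(Cc2ccccc2)c1`, gives >= 144 ug/mL in a physicochemical assay for solubility; a higher number here means a more soluble compound, a lower number a less soluble compound; this value is a limit of the assay.
Compound 2, `CNC(=O)c1cc(C(=O)NC2CC2)cn(Cc2cccc3[nH]ccc23)c1=O`, gives 78 ug/mL in this assay.
Compound 3, `CNC(=O)c1cc(C(=O)NC2CC2)cn(Cc2cccc3cn[nH]c23)c1=O`, gives >= 181 ug/mL in this assay; this value is a limit of the assay.

Compound 1 stands at a limit, so only a floor for its solubility is known (the limit of >= 144 ug/mL in this assay, at which 1 of the 3 values shown sits). Compound 3 also sits at a limit (the limit of >= 181 ug/mL in this assay, at which 1 of the 3 values shown sits). Among the compounds with values here, the one step that can be sized within the set is an at least 2.3-fold higher number from compound 2 to compound 3 (0.36 log units; beyond the scatter), which swaps one ring system for another on the chain carbon bound to the ring nitrogen and does not touch the amide chains.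

Compound 4, `CNC(=O)c1cc(C(=O)NCCOC)cn(Cc2ccccc2)c1=O`, differs from compound 1 by methoxy in place of hydrogen on a saturated chain carbon, two bonds along the chain from an amide-type nitrogen. Within the data shown here, no measured pair changes that position, so the step from compound 2 to compound 3 speaks to it only in showing that a single small change can move this readout beyond the scatter. Compound 1 already lies at a limit, which leaves little room to read a rise and no measured basis to expect a fall. The expectation for compound 4 is therefore a step that the limit leaves unreadable from compound 1 to compound 4, that is, a solubility near or above the floor seen for compound 1. Compound 4 is estimated at 180 ug/mL, within 100 ug/mL to 320 ug/mL in this assay.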

Compound 4, solubility: >= 164 ug/mL
Compound 4: no number, only a limit; the forecaster's own chance of this, stated with the estimate: 60%; the middle value does not contradict the limit.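

Compound 1 and compound 4 both stand at a limit in this assay, so no size or direction can be read for the step between them. The compounds shown leave open how far either true value lies past its limit, and so whether methoxy in place of hydrogen changes this read-out at all.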